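Working notes: series around compounds 1 to 4

The compounds below may be only part of what the source reports. "The series", "measured", "known", "first", "only" and "open" are said of these compounds alone.

Compound 1 `CC(C)C[C@H](N)CN(C(=O)[C@@H]1C[C@H]1c1ccccc1)c1ccc(-c2ccccc2)cc1` gives 880 nM in a functional assay for agonist activity at G protein-coupled receptor 88 (Homo sapiens), read by HTRF and cAMP accumulation; on this read-out higher numbers stand for an effect only at larger amounts of compound and lower numbers for an effect already at smaller amounts. Compound 2 `N[C@H](CN(C(=O)[C@@H]1C[C@H]1c1ccccc1)c1ccc(-c2ccccc2)cc1)C1CCCCC1` gives 0.66 nM, and compound 3 `CC(C)[C@H](N)CN(C(=O)[C@@H]1C[C@H]1c1ccccc1)c1ccc(-c2ccccc2)cc1` gives 1.1 nM; compound 3 thus sits second highest of three, close to compound 2 and far from compound 1. Compound 4 `O=C([C@@H]1C[C@H]1c1ccccc1)N(CC1CCCNC1)c1ccc(-c2ccccc2)cc1` differs by piperidin-3-yl in place of 1-amino-2-methylpropyl on a saturated chain carbon bound to an amide-type nitrogen. The measured steps of a 1300-fold lower number from compound 1 to compound 2 (3.12 log units; beyond the scatter), an 800-fold lower number from compound 1 to compound 3 (2.90 log units; beyond the scatter) and a 1.7-fold higher number from compound 2 to compound 3 (0.22 log units; within the scatter) all concern the substituent on the amine-bearing carbon, not the placement of the amine itself, so none bears directly on this change. With the amine moved into a ring, a step of a 270-fold higher number from compound 3 to compound 4 (2.44 log units; beyond the scatter) towards a higher number is expected. Compound 4 is estimated at 300 nM, between 20 nM and 4000 nM.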

Compound 4, half-maximal effective concentration: 10 nM
The estimate for compound 4 lay 30-fold (1.48 log units) above the measured number; the whole stated range lies above it.
By their numbers in this assay, from the lowest: compounds 2 and 3 (each within the scatter of the next); then compound 4; then compound 1.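

In this assay, an amine held in a piperidin-3-yl ring on the saturated chain carbon bound to an amide-type nitrogen remains active at low concentration, with a 9.1-fold higher number from compound 3 to compound 4 (0.96 log units; beyond the scatter) and a 15-fold higher number from compound 2 to compound 4 (1.18 log units; beyond the scatter), but also an 88-fold lower number from compound 1 to compound 4 (1.94 log units; beyond the scatter). This position therefore does not require an open-chain amine, and the ring form falls in the wide gap left by the open-chain substituents. Nothing available accounts for these differences. As far as these compounds go, the single enantiomers of piperidin-3-yl remain open. So do piperidin-4-yl and pyrrolidin-3-yl at this position.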